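Shortening the side chain of the thiourea series

The source may hold more compounds than are shown below. What is called first, only, known or untested is meant among the compounds shown, and "the series" means these compounds.

Compound 3 `CC(C)C[C@@H](NC(=S)Nc1cc(C(F)(F)F)cc(C(F)(F)F)c1)c1nc2ccccc2[nH]1` gives 10400 nM in a functional assay on HeLa cells (Homo sapiens) for cytotoxicity, read by MTT assay (on this read-out lower numbers stand for stronger inhibition and higher numbers for weaker inhibition), the lowest number among the three measured; compound 1 `CC(C)C[C@H](NC(=S)Nc1ccccc1)c1nc2ccccc2[nH]1` gives 29100 nM and compound 2 `CC(C)C[C@H](NC(=S)NCc1ccccc1)c1nc2ccccc2[nH]1` gives 31200 nM, both beyond the scatter from compound 3. Within the data shown here, the only measured step, a 1.1-fold higher number from compound 1 to compound 2 (0.03 log units; within the scatter), concerns the group on the thiourea and not the side chain, so it does not bear on the change to compound 4 `C[C@@H](NC(=S)Nc1cc(C(F)(F)F)cc(C(F)(F)F)c1)c1nc2ccccc2[nH]1`, which is hydrogen in place of isopropyl on a saturated chain carbon, two bonds along the chain from an amide-type nitrogen and an aromatic carbon. Among the measured compounds shown here, no measured pair shows the consequence of removing isopropyl here. Compound 4 is therefore expected to move only modestly, by a 1.7-fold higher number from compound 3 to compound 4 (0.24 log units; within the scatter), with a wide range. The estimate for compound 4 is 18000 nM, between 8000 nM and 45000 nM.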

Compound 4, half-maximal inhibitory concentration: 16100 nM
For compound 4 the middle estimate is 1.1-fold (0.05 log units) above the measured one; measured number inside the range.
By their numbers in this assay, from the lowest: compounds 3, 4, 1 and 2 (each within the scatter of the next, the first and the last beyond it).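

Hydrogen in place of isopropyl on this saturated chain carbon gives a 1.5-fold higher number from compound 3 to compound 4 (0.19 log units; within the scatter) in this assay. Among these compounds, the first measured change at this position therefore shows that, with the thiourea group of compound 3, cutting isobutyl to methyl leaves the number within the scatter. No available evidence explains this result.

Still open, as far as these compounds go, is whether a longer chain, an amine or a carboxylic acid at this place would keep the number at this level. Also open, from the compounds shown here alone, is whether the same change would read alike with the phenyl group of compound 1.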